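Aromatic substituent swaps in the alkynyl lactam series

The source may hold more compounds than are shown below. What is called first, only, known or untested is meant among the compounds shown, and "the series" means these compounds.

Compound 1 `Cc1cccc(C#Cc2ccc3c(n2)CCN(C)C3=O)c1`: 820 nM
Compound 2 `CN1CCc2nc(C#Cc3cccc(Cl)c3)ccc2C1=O`: 250 nM

In an assay on HEK293 cells for displacement of a labelled ligand from metabotropic glutamate receptor 5 (Homo sapiens), with a stated time of 2 h (on this read-out lower numbers stand for stronger inhibition and higher numbers for weaker inhibition), compound 2 stands lowest of the two numbers, with compound 1 the only comparator; the step of a 3.3-fold lower number from compound 1 to compound 2 (0.52 log units; beyond the scatter) lies beyond the scatter. Compound 3 `COc1cccc(C#Cc2ccc3c(n2)CCN(C)C3=O)c1` is not yet measured. Relative to compound 2 it carries methoxy in place of chloro on an aromatic carbon, on an aromatic carbon of a six-membered aromatic ring of carbon only, meta to a large group. Among the measured compounds shown here, the one measured step at this position, a 3.3-fold lower number from compound 1 to compound 2 (0.52 log units; beyond the scatter), exchanges methyl for chloro; no measured step exchanges chloro for methoxy, so the size is uncertain. For compound 3 the step of a 2.2-fold higher number from compound 2 to compound 3 (0.34 log units; beyond the scatter) is expected to be modest, toward a higher number. Compound 3 is estimated at 550 nM, range 150 nM to 2000 nM.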

Compound 3, inhibition constant: 3660 nM
Compound 3: middle estimate off by 6.7-fold (0.82 log units), on the low side; measured number above the stated range.
By their numbers in this assay, from the lowest: compound 2; then compound 1; then compound 3.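

In this assay methoxy on the aromatic carbon meta to a large group gives the highest number of the three groups, which the methyl and chloro pair could not show. The step of a 15-fold higher number from compound 2 to compound 3 (1.17 log units; beyond the scatter) is large, and the step of a 4.5-fold higher number from compound 1 to compound 3 (0.65 log units; beyond the scatter) places methoxy above methyl as well, so the order at this position runs chloro, methyl, methoxy. Nothing at hand accounts for this order. On these data alone, whether an amine, a fluoro group or a longer ether chain at this carbon would follow that order remains open, as does whether the order holds on other carbons of the ring.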